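The compounds below may be only part of what the source reports. "The series", "measured", "known", "first", "only" and "open" are said of these compounds alone.

Compound 1 `Brc1cn2ccnc2c(-c2ccc3ncn(C4CCCCC4)c3c2)n1` is the point from which the step sets out. In a functional assay on DU-145 cells (Homo sapiens) for inhibition, read by sulforhodamine B assay, with a stated time of 48 h, tested at 10 uM (on this read-out lower numbers stand for less inhibition and higher numbers for more inhibition at the one concentration tested (going by the name of the read-out)), compound 1 gives 6.2% and stands second highest of the three measured compounds. Its nearest neighbour is compound 3 `c1ccc2c(-c3cn4ccnc4c(-c4ccc5ncn(C6CCCCC6)c5c4)n3)cccc2c1`, which in this assay gives 5.1%; the step of a number 1.1 percentage points lower from compound 1 to compound 3 (within the scatter) lies within the scatter. Furthest from it is compound 2 `COc1ccc(-c2cn3ccnc3c(-c3ccc4ncn(C5CCCCC5)c4c3)n2)cc1`, which in this assay gives 81.8%; the step of a number 75.6 percentage points higher from compound 1 to compound 2 (beyond the scatter) is large. Compound 4 `Brc1ccc(-c2cn3ccnc3c(-c3ccc4ncn(C5CCCCC5)c4c3)n2)cc1` differs from compound 1 in a single place: 4-bromophenyl in place of bromo on an aromatic carbon. Among the measured compounds shown here, two measured steps bear on this change, each replacing the bromo group of compound 1 with an aromatic ring: the step of a number 75.6 percentage points higher from compound 1 to compound 2 (beyond the scatter) is large, whereas the step of a number 1.1 percentage points lower from compound 1 to compound 3 (within the scatter) stays within the scatter. The 4-bromophenyl group entering in compound 4 is, like the 4-methoxyphenyl group of compound 2, one six-membered aromatic ring of carbon only carrying a single group, rather than the naphthalen-1-yl group of compound 3. Compound 4 is therefore expected to come out higher, estimated at 55% with a range from 15% to 90%. The expected step of a number 48.8 percentage points higher from compound 1 to compound 4 (beyond the scatter) is thought to lie beyond the scatter, though with considerable uncertainty given the two contrasting precedents.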

Compound 4, a percentage reported as inhibition, at one concentration (the size of the read-out at that concentration, not a potency): 5.66%
The estimate for compound 4 lay 49.3 percentage points above the measured number, and the stated range ends above it.
By their numbers in this assay, from the lowest: compounds 3, 4 and 1 (each within the scatter of the next); then compound 2.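

In this assay, putting a single six-membered aromatic ring of carbon only at this position does not by itself bring the high number seen for compound 2: a number 0.5 percentage points lower from compound 1 to compound 4 (within the scatter), and a number 0.6 percentage points higher from compound 3 to compound 4 (within the scatter). The large step instead appears with the group carried on that ring, with bromo in place of methoxy: a number 76.1 percentage points lower from compound 2 to compound 4 (beyond the scatter). Nothing available accounts for this sharp difference between the two groups.

The compounds shown leave open whether the high number is particular to methoxy or also appears with other groups on the ring, such as hydroxyl, an amine or ethoxy. They also leave open how compound 2 and compound 4 would compare at concentrations other than the one tested.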